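A Methyl Added to a Compound at the Limit

This account rests on a few compounds, and the source may have more. Where it says the series, first, only, none or still open, it means among the compounds named here.

Measured so far in a functional assay on the whole organism for antagonist activity, with Mus musculus as the target; on this read-out higher numbers stand for an effect only at larger amounts of compound and lower numbers for an effect already at smaller amounts

- Compound 1 (`COC(=O)N(C)C(C)C#CCn1ccnc1`) gives > 100 mg/kg as a limit
- Compound 2 (`CCOC(=O)N(C)C(C)C#CCn1cncc1C`) gives 30 mg/kg as a number
- Compound 3 (`O=C1NCCN1CC#CCn1ccnc1`) gives > 100 mg/kg as a limit

Compound 3 stands at the limit of > 100 mg/kg in this assay, at which 2 of the 3 values shown sit, and carries no number. Its true position could lie anywhere beyond that limit, so it offers a starting point without an exact value.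

Compound 4 (`Cc1cncn1CC#CCN1CCNC1=O`) is compound 3 with a single change: methyl in place of hydrogen on an aromatic carbon. Going by the values given here, no pair of measured compounds shows this change on its own, so any forecast rests on thin evidence. Among the compounds with values here, the one clue is compound 2, which also carries a methyl on this ring and gives 30 mg/kg as the only real number in this assay so far. On that basis, an effect at smaller amounts is expected for the methyl compound. The expected size of the change is an at least 2.5-fold lower number from compound 3 to compound 4 (0.39 log units; beyond the scatter) and it remains uncertain on the side of compound 3. For compound 4 the estimated value is 40 mg/kg with an expected range from 12 mg/kg to 130 mg/kg and a real chance of only a limit.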

Compound 4, dose for half-maximal effect: > 100 mg/kg
Compound 4: only a limit was reported; the forecaster's own chance of this, stated with the estimate: 35%; middle value at least 2.5-fold (0.39 log units) away from the limit.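

No step can be read from compound 3 to compound 4, because both give only a limit and no number: the limit of > 100 mg/kg in this assay, at which 3 of the 4 values shown sit.

The compounds shown leave open whether methyl in place of hydrogen on an aromatic carbon changes the dose needed in this assay at all, and if so, by how much.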